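A Piperidinyl in Place of a Methylsulfonyl

The source may report more compounds than this note shows. Statements on the series, on what has been measured and on what is new or still open speak of the compounds shown alone.

Going by the values given here, compound 2 `Cc1cnc(Nc2ccc(S(C)(=O)=O)cc2)nc1Nc1nc2ccccc2s1` gives 6550 nM in a functional assay on MCF7 cells (Homo sapiens) for antiproliferative activity, read by MTT assay, with a stated time of 48 h (on this read-out higher numbers stand for weaker inhibition and lower numbers for stronger inhibition), and stands second highest of the three numbers known so far. Compound 1 `Cc1cnc(Nc2ccc(S(C)(=O)=O)cc2)nc1Nc1nc2ccc(Cl)cc2s1` gives 4320 nM in this assay, and compound 3 `CS(=O)(=O)c1ccc(Nc2nccc(Nc3nc4ccccc4s3)n2)cc1` gives 10600 nM; the steps of a 1.5-fold higher number from compound 1 to compound 2 (0.18 log units; within the scatter) and a 1.6-fold higher number from compound 2 to compound 3 (0.21 log units; within the scatter) were both within the scatter. Compound 4 `Cc1cnc(Nc2ccc(N3CCCCC3)cc2)nc1Nc1nc2ccccc2s1` differs from compound 2 by piperidin-1-yl in place of methylsulfonyl on an aromatic carbon. Neither measured step touches that group or that place, so neither bears directly on this change; with no guide in either direction, one expects no step beyond the scatter, only a wide uncertainty. The expected step is a 1.3-fold lower number from compound 2 to compound 4 (0.12 log units; within the scatter). Compound 4 is estimated at 5000 nM, within a range from 1200 nM to 20000 nM.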

Compound 4, half-maximal inhibitory concentration: > 50000 nM
Compound 4: a limit, no number (the forecaster's own chance of this, stated with the estimate: 10%); middle value at least 10-fold (1.00 log units) away from the limit.
By their numbers in this assay, from the lowest: compounds 1, 2 and 3 (each within the scatter of the next, the first and the last beyond it). At a limit, above all of these: compound 4.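

Compound 4 stands at a limit in this assay, not at a number: the limit of > 50000 nM in this assay, at which 1 of the 4 values shown sits. The chloro and methyl steps stayed within the scatter, but piperidin-1-yl in place of methylsulfonyl on this aromatic carbon gives an at least 7.6-fold higher number from compound 2 to compound 4 (0.88 log units; beyond the scatter), so this is the first change shown to go beyond it. The true size of this step cannot be read from a limit.

The compounds shown leave open whether the change in read-out follows from losing methylsulfonyl or from gaining piperidin-1-yl. They also leave open how a carboxylic acid or an open-chain amine would read at this place.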